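The source may report more compounds than this note shows. Statements on the series, on what has been measured and on what is new or still open speak of the compounds shown alone.

Of the compounds shown here, three built on one shared core have been tested in an assay on isolated protein for inhibition of P2X purinoceptor 7 (Homo sapiens); on this read-out lower numbers stand for stronger inhibition and higher numbers for weaker inhibition. Compound 1 `CCN1C(=O)CC[C@H]1C(=O)NCc1ccc(Cl)cc1` gives 631 nM in this assay. Compound 2 `CCN1C(=O)CC[C@H]1C(=O)NCc1cccc(C(F)(F)F)c1` gives 100 nM in this assay; how its core differs from that of compound 1 is not broken down here. Compound 3 `CCN1C(=O)CC[C@H]1C(=O)NCc1ccc(Cl)cc1Cl` gives 6.31 nM in this assay. From compound 1 to compound 3 the change is chloro in place of hydrogen on an aromatic carbon, and it made a 100-fold lower number from compound 1 to compound 3 (2.00 log units; beyond the scatter).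

Compound 4 `CCN1C(=O)CC[C@H]1C(=O)NCc1cccc(C(F)(F)F)c1Cl` has not yet been measured. It arises from compound 2 by chloro in place of hydrogen on an aromatic carbon. Within the data shown here, this is the same kind of change as the one from compound 1 to compound 3, though not the same: in compound 3 the entering chloro sits meta to a chloro group, whereas in compound 4 it sits ortho to a trifluoromethyl group. Because the earlier step of a 100-fold lower number from compound 1 to compound 3 (2.00 log units; beyond the scatter) was large, a lower number is expected here too, but the different surroundings make its size less certain. The expected step is a 13-fold lower number from compound 2 to compound 4 (1.10 log units; beyond the scatter). Compound 4 is therefore estimated to give about 8 nM in this assay, most likely between 2 nM and 40 nM.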

Compound 4, half-maximal inhibitory concentration: 1.59 nM
Compound 4: the middle estimate sits 5.0-fold (0.70 log units) above what was measured, outside the stated range (below it).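

Putting chloro in place of hydrogen on an aromatic carbon gave a 63-fold lower number from compound 2 to compound 4 (1.80 log units; beyond the scatter) in this assay, so a large step in the same direction appeared on a second core. Among these compounds, in this series, then, the change carried from one core to the other with much the same size, even though the groups already on the aromatic ring were not the same: the same change on two cores in this assay, a 100-fold lower number (2.00 log units; beyond the scatter) from compound 1 to compound 3 and a 63-fold lower number (1.80 log units; beyond the scatter) from compound 2 to compound 4, 1.6-fold (0.20 log units) apart, within the scatter of two such steps Still, these are only two pairs of compounds, so they cannot show that the step would hold on any further core, and they do not explain why adding the chloro lowers the number.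

The compounds shown leave open whether another group entering at that place, such as a bromo, a methoxy or a nitrile, would give a step of similar size. They also leave open whether the step would survive if a longer chain or an amine replaced the ethyl group on the shared core.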